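Two Amines Measured, a Third Estimated for Stability

The source may report more compounds than this note shows. Statements on the series, on what has been measured and on what is new or still open speak of the compounds shown alone.

Compound 1 `c1ccc2c(c1)CN[C@@H](CN(CC1CCNCC1)[C@H]1CCCc3cccnc31)C2`: 86%
Compound 2 `c1cnc(CN(CCCN2CCNCC2)[C@H]2CCCc3cccnc32)nc1`: 100%

In an ADME assay on microsomes from liver (Homo sapiens) for metabolic stability, read by LC-MS, with a stated time of 10 min, tested at 0.5 uM (a lower number here means that less of the compound is left, a higher number that more of the compound is left), compound 2 gives 100%, the highest of the two numbers; the nearest, compound 1, lies a step lower that falls beyond the usual scatter. Compound 3 `c1cnc2c(c1)CN[C@H](CN(CCCN1CCNCC1)[C@H]1CCCc3cccnc31)C2` is not yet measured. It differs from compound 2 by a group of 10 heavy atoms (8 carbon, 2 nitrogen; one six-membered non-aromatic ring with 1 hetero atom, one six-membered aromatic ring with 1 hetero atom) in place of a group of 6 heavy atoms (4 carbon, 2 nitrogen; one six-membered aromatic ring with 2 hetero atoms), on a saturated chain carbon bound to an amine nitrogen. Within the data shown here, no measured pair shares this change, so its size is uncertain. Because compound 1, which carries a closely similar group, gives 86%, a modest fall is expected in this assay, a number 12 percentage points lower from compound 2 to compound 3 (beyond the scatter). Compound 3 is therefore estimated at 88%, between 72% and 100%.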

Compound 3, percent of the compound remaining: 100%
Beside the measured number, compound 3's estimate is 12 percentage points below it; the range from low to high includes it.
By their numbers in this assay, from the lowest: compound 1; then compounds 2 and 3 (each within the scatter of the next).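

In this assay the pyrimidin-2-yl group gives way to the larger two-ring group, which adds a hydrogen-bond donor and a defined stereocentre, on a saturated chain carbon bound to an amine nitrogen, with no change at the digits printed from compound 2 to compound 3 (within the scatter) as the result. Among these compounds, this is the first step read at this position, and it shows that this place takes the much larger group with no loss in the compound remaining. No measured data on hand explain this outcome.

The compounds shown leave open how a phenyl ring or a carboxylic acid would read on that chain carbon. They also leave open how a shorter chain in place of the propyl chain bearing the piperazine would read.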